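The source may report more compounds than this note shows. Statements on the series, on what has been measured and on what is new or still open speak of the compounds shown alone.

Measured in a functional assay on HCT-116 cells (Homo sapiens) for inhibition, read by CCK-8 assay, with a stated time of 48 h; on this read-out lower numbers stand for stronger inhibition and higher numbers for weaker inhibition:

- compound 1 `COc1cc(-c2ccnc3cc(-c4ccc(C)cc4)nn23)cc(OC)c1OC` gives 48 nM
- compound 2 `COc1cc(-c2ccnc3cc(-c4ccc5cc[nH]c5c4)nn23)cc(OC)c1OC` gives 187 nM
- compound 3 `COc1ccc(-c2cc3nccc(-c4cc(OC)c(OC)c(OC)c4)n3n2)cc1` gives 404 nM

Compound 3 has the highest number of the three and is therefore the weakest inhibitor here. Compound 4 `COc1ccc(-c2cc3nccc(-c4cc(OC)c(OC)c(OC)c4)n3n2)cc1N` keeps the core of compound 3 and differs only in its 4-methoxyphenyl, which becomes 3-amino-4-methoxyphenyl: amino in place of hydrogen on an aromatic carbon, ortho to a methoxy group (amino in place of hydrogen on an aromatic carbon). Among the compounds with values here, no measured step adds an amino group, so the evidence is indirect. The closest steps change the aryl group at this same place: an 8.4-fold higher number from compound 1 to compound 3 (0.93 log units; beyond the scatter) and a 2.2-fold higher number from compound 2 to compound 3 (0.33 log units; beyond the scatter). Both are modest, and both show that other aryl groups here give lower numbers than 4-methoxyphenyl. A modest step towards a lower number is therefore expected in this assay, although the uncertainty is wide. The expected step is a 3.4-fold lower number from compound 3 to compound 4 (0.53 log units; beyond the scatter). In this assay the estimate for compound 4 is 120 nM, with an expected range from 25 nM to 500 nM.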

Compound 4, half-maximal inhibitory concentration: 251 nM
For compound 4 the middle estimate is 2.1-fold (0.32 log units) below the measured one; measured number inside the range.
By their numbers in this assay, from the lowest: compound 1; then compounds 2, 4 and 3 (each within the scatter of the next, the first and the last beyond it).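

In this assay, placing an amino group on the aromatic carbon ortho to a methoxy group gives a 1.6-fold lower number from compound 3 to compound 4 (0.21 log units; within the scatter), so at this position the added group does not move the number beyond the scatter. The 3-amino-4-methoxyphenyl group also stays within the scatter of 1H-indol-6-yl, with a 1.3-fold higher number from compound 2 to compound 4 (0.13 log units; within the scatter), while 4-methylphenyl remains clearly apart, with a 5.2-fold higher number from compound 1 to compound 4 (0.72 log units; beyond the scatter). Nothing measured here bears on the cause of these results.

The compounds shown leave open how a hydroxy, an acetamido or a dimethylamino group would read at this same place. They also leave open whether an amino group would have a similarly small step on the 4-methylphenyl ring of compound 1, which has the lowest number of the set.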